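Working notes: from compound 2 to compound 3

This account rests on a few compounds, and the source may have more. Where it says the series, first, only, none or still open, it means among the compounds named here.

Measured so far in an ADME assay (liver) for metabolic stability, with Liver microsome (Homo sapiens) as the target, using microsomes (on this read-out higher numbers stand for a longer-lived compound and lower numbers for a shorter-lived compound), are two compounds:
- compound 1 `CC(C)c1nc2ccccn2c1C(=O)NCc1ccc(-c2ccccc2)cc1` with 0.527 h as its half-life
- compound 2 `CCc1nc2ccc(Cl)cn2c1C(=O)NCc1ccc(-c2ccccc2Cl)cc1` with 0.648 h as its half-life

Compound 2 stands level with compound 1, since the two values lie within the usual scatter of each other and neither can be ranked ahead. For the measured compounds named here, the series has no measured pair that differs in one place only, so no direct precedent exists for the next change.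

Compound 3 `CCc1nc2ccc(Cl)cn2c1C(=O)NCc1ccc(-c2ccc(C)cc2)cc1` carries 4-methylphenyl in place of 2-chlorophenyl on an aromatic carbon. The data give no sign of how this assay responds to this swap. Going by the values given here, the only guide is that compound 1 at 0.527 h and compound 2 at 0.648 h sit close together. No step beyond the scatter is therefore expected, with at most a slight, unresolved drift towards a shorter-lived compound. The estimated change is a 1.3-fold lower number from compound 2 to compound 3 (0.11 log units; within the scatter) and it would remain within the scatter. The estimate for compound 3 is 0.5 h (expected range 0.25 h to 1 h).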

Compound 3, half-life: 0.508 h
The estimate for compound 3 lay 1.0-fold (0.01 log units) below the measured number; the range from low to high includes it.
By their numbers in this assay, from the lowest: compounds 3, 1 and 2 (each within the scatter of the next).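

Series notes, aryl position: in this assay putting 4-methylphenyl in place of 2-chlorophenyl gives a 1.3-fold lower number from compound 2 to compound 3 (0.11 log units; within the scatter) and this is the only pair in the series that differs in one place. For the compounds shown here, it is therefore the only direct reading of this position, on an aromatic carbon para to a large group, and the half-life does not separate the two groups, although one carries chlorine and the other a methyl in its place on the ring. No measurement available here bears on why the two half-lives stand level.

Going by these compounds alone, the single swap changes both the kind of group on the outer ring and where it sits on that ring, so the contribution of each remains unresolved, and any value of this position beyond the scatter is still unknown. An amine or a carboxylic acid on this outer ring, which would bring in atoms other than carbon and chlorine, would show whether the half-life responds at this position at all.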